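Trifluoromethyl replaces hydroxy: compound 3 in the chalcone-boronate set

The source may report more compounds than this note shows. Statements on the series, on what has been measured and on what is new or still open speak of the compounds shown alone.

Two members of the series are measured so far; they share one core and differ only in the group on the aromatic ring of the ketone side. Compound 1 `O=C(/C=C/c1ccc2c(c1)B(O)OC2)c1ccc(Cl)cc1` carries chloro there, and in a functional assay on HCT-116 cells (Homo sapiens) for cytotoxicity, read by MTT assay, with a stated time of 48 h (on this read-out lower numbers stand for stronger inhibition and higher numbers for weaker inhibition), compound 1 gives 9300 nM. Among the measured compounds shown here, compound 2 `O=C(/C=C/c1ccc2c(c1)B(O)OC2)c1ccc(O)cc1` carries hydroxy, and in this assay compound 2 gives 24100 nM, the highest of the two numbers known; the only step measured, a 2.6-fold higher number from compound 1 to compound 2 (0.41 log units; beyond the scatter), is modest but beyond the scatter.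

Compound 3 `O=C(/C=C/c1ccc2c(c1)B(O)OC2)c1ccc(C(F)(F)F)cc1` is the next member: trifluoromethyl in place of hydroxy on an aromatic carbon. For the measured compounds named here, no measured step covers this exact change. Going by the values given here, the one step that bears on it does so indirectly: leaving chloro for hydroxy raised the number, so leaving hydroxy again for a group other than hydroxy could plausibly return the number toward that of compound 1, though nothing measured says how far. Compound 3 is therefore expected in this assay at about 10000 nM, within 4000 nM to 30000 nM. Among the compounds with values here, the expected step, a 2.4-fold lower number from compound 2 to compound 3 (0.38 log units; beyond the scatter), would be a modest lowering, close to the size of the one step seen.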

Compound 3, half-maximal inhibitory concentration: 6300 nM
For compound 3 the middle estimate is 1.6-fold (0.20 log units) above the measured one, within the range that was stated.
By their numbers in this assay, from the lowest: compounds 3 and 1 (each within the scatter of the next); then compound 2.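

Working notes on the ketone-side aromatic ring: in this assay, trifluoromethyl in place of hydroxy gives a 3.8-fold lower number from compound 2 to compound 3 (0.58 log units; beyond the scatter), a modest step beyond the scatter, and with the earlier chloro-to-hydroxy step this sets hydroxy apart as the group with the weakest inhibition of the three at this position, para to a large group. The step of a 1.5-fold lower number from compound 1 to compound 3 (0.17 log units; within the scatter) lies within the scatter, so chloro and trifluoromethyl are not separated on this read-out, and the series now shows two interchangeable groups here against one that stands apart, rather than a single pairwise difference. Nothing at hand explains this pattern.

Still open, going by these compounds, is whether an amine, a methoxy group or a carboxylic acid at this position would fall with hydroxy or with the chloro and trifluoromethyl pair, and whether a longer chain would be accepted at all. Also open, on these data alone, is whether the same grouping of substituents holds on a changed core or in cell lines other than the one in this assay.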